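A few compounds are considered here, and "the series" means these few. Any claim that something is new, unique, unknown or untested is made for them only; others in the source may bear on it.

Series notes. Compound 1 `C=C1C(=O)O[C@@H]2CC(C)=C([C@@H](C)CCCOC(C)=O)[C@@H](OC(=O)COc3ccc([N+](=O)[O-])cc3[N+](=O)[O-])[C@H]12` returns only a limit in a functional assay on HeLa cells (Homo sapiens) for cytotoxicity, read by sulforhodamine B assay, with a stated time of 72 h (on this read-out higher numbers stand for weaker inhibition and lower numbers for stronger inhibition), giving > 100000 nM. Compound 2 `C=C1C(=O)O[C@@H]2CC(C)=C([C@@H](C)CCCOC(C)=O)[C@@H](OC(=O)c3ccc(C)cc3)[C@H]12` gives 5460 nM in this assay. Compound 3 `CC(=O)OCCC[C@H](C)C1=C(C)C[C@H]2OC(=O)C(CSCCO)[C@H]2[C@@H]1OC(C)=O` likewise returns only a limit, with > 100000 nM in this assay. Where compound 3 stands is thus a limit and not a number, a position shared with one other shown value: the limit of > 100000 nM in this assay, at which 2 of the 3 values shown sit. Compound 4 `CC(=O)OCCC[C@H](C)C1=C(C)C[C@H]2OC(=O)C(CSCCO)[C@H]2[C@@H]1OC(=O)c1ccccc1` is still to be measured in this assay. The change from compound 3 is phenyl in place of methyl on a carbonyl carbon. Among the measured compounds shown here, no step between measured compounds covers this change. Since compound 3 sits at the limit, no movement beyond the scatter is expected. The step from compound 3 to compound 4 is estimated as an at least 1.6-fold lower number from compound 3 to compound 4 (0.22 log units; that floor lies within the scatter). Compound 4 is expected near 60000 nM, within a range of 15000 nM to 100000 nM.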

Compound 4, half-maximal inhibitory concentration: > 100000 nM
Compound 4 gave a limit, no number; the forecaster's own chance of this, stated with the estimate: 50%; middle value at least 1.6-fold (0.22 log units) away from the limit.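

Compound 3 and compound 4 each return only a limit, so no step can be read between them: the limit of > 100000 nM in this assay, at which 3 of the 4 values shown sit. Going by these compounds, whether phenyl in place of methyl on a carbonyl carbon shifts the number in this assay remains open.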